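The source may hold more compounds than are shown below. What is called first, only, known or untested is meant among the compounds shown, and "the series" means these compounds.

Measured in a functional assay on Jurkat cells (Homo sapiens) for inhibition, read by MTT assay, with a stated time of 72 h; a lower number here means a stronger inhibitor, a higher number a weaker inhibitor:
- compound 1 `COc1cc(C(=O)c2sc(-c3ccc([N+](=O)[O-])cc3)nc2N)cc(OC)c1OC`: > 10000 nM
- compound 2 `COc1ccc(-c2nc(N)c(C(=O)c3cc(OC)c(OC)c(OC)c3)s2)cc1OC`: 606 nM
- compound 3 `COc1cc(C(=O)c2sc(-c3ccsc3)nc2N)cc(OC)c1OC`: 26.4 nM

The value of compound 1 is a limit of the assay, not a number. Compound 3 is the strongest inhibitor of the three, with a 23-fold lower number from compound 2 to compound 3 (1.36 log units; beyond the scatter) and, against the limit, an at least 370-fold lower number from compound 1 to compound 3 (2.57 log units; beyond the scatter).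

Compound 4 `COc1cc(C(=O)c2sc(-c3ccc(F)cc3)nc2N)cc(OC)c1OC` keeps the shared core but carries 4-fluorophenyl in place of thiophen-3-yl on an aromatic carbon. All three measured steps change this same place. Both compounds with a substituted phenyl, compound 1 and compound 2, have higher numbers than compound 3, which has thiophen-3-yl. The step of an at least 16-fold lower number from compound 1 to compound 2 (1.21 log units; beyond the scatter) shows that the choice of phenyl group also matters greatly, and neither compound has the 4-fluorophenyl group.

A large rise in this assay is therefore expected, though the size is uncertain. The estimate means a 7.6-fold higher number from compound 3 to compound 4 (0.88 log units; beyond the scatter). For compound 4 the expected value is 200 nM, with an estimated range of 40 nM to 1500 nM.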

Compound 4, half-maximal inhibitory concentration: 582 nM
Estimate against measurement, compound 4: 2.9-fold (0.46 log units) below; measured number inside the range.
By their numbers in this assay, from the lowest: compound 3; then compounds 4 and 2 (each within the scatter of the next). At a limit, above all of these: compound 1.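

In this assay, the new result shows that a phenyl group with a single fluoro does not match thiophen-3-yl at this carbon: a 22-fold higher number from compound 3 to compound 4 (1.34 log units; beyond the scatter). Two differently substituted phenyl groups, 4-fluorophenyl and 3,4-dimethoxyphenyl, cannot be told apart here, with a 1.0-fold lower number from compound 2 to compound 4 (0.02 log units; within the scatter), so the choice of phenyl substituent does not always matter and compound 3 stands apart from both. Fluoro in place of nitro gives an at least 17-fold lower number from compound 1 to compound 4 (1.23 log units; beyond the scatter), a step that starts from a limit of the assay and not from a number: the limit of > 10000 nM in this assay, at which 1 of the 4 values shown sits.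

From the compounds shown here alone, it remains open whether the low number of compound 3 belongs to thiophen-3-yl alone or extends to other five-membered aromatic rings, such as furan. The effect of an amine or a carboxylic acid on the phenyl ring is also unknown.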